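The compounds below may be only part of what the source reports. "The series", "measured", "known", "first", "only" and "open" are said of these compounds alone.

For the measured compounds named here, in a functional assay on A549 cells (Homo sapiens) for cytotoxicity, read by MTT assay, with a stated time of 72 h (on this read-out higher numbers stand for weaker inhibition and lower numbers for stronger inhibition), compound 2 (`CC1(C)OC[C@@H](Cn2cc(Cn3c4c(c5ccccc53)C(=O)c3c[n+]([O-])c5ccccc5c3C4=O)nn2)O1`) gives 4700 nM, the higher of the two numbers so far. Compound 1 (`CC1(C)OC[C@H](Cn2cc(Cn3c4c(c5ccccc53)C(=O)c3c[n+]([O-])c5ccccc5c3C4=O)nn2)O1`) gives 340 nM. The large step between them, a 14-fold higher number from compound 1 to compound 2 (1.14 log units; beyond the scatter), goes with the fact that compounds 1 and 2 differ only in the configuration as drawn. Compound 3 (`O=C1c2c[n+]([O-])c3ccccc3c2C(=O)c2c1c1ccccc1n2Cc1cn([C@H]2C[C@H](O)[C@@H](CO)O2)nn1`) has 4-hydroxy-5-(hydroxymethyl)oxolan-2-yl in place of (2,2-dimethyl-1,3-dioxolan-4-yl)methyl on an aromatic nitrogen. That one measured step shows how far a small change in this group can move the number, but it does not fix a direction here. The expected change is a 2.4-fold lower number from compound 2 to compound 3 (0.37 log units; beyond the scatter), a moderate move towards stronger inhibition. For compound 3 the estimate is 2000 nM, with an expected range of 300 nM to 12000 nM.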

Compound 3, half-maximal inhibitory concentration: 350 nM
Compound 3: middle estimate off by 5.7-fold (0.76 log units), on the high side, within the range that was stated.
By their numbers in this assay, from the lowest: compounds 1 and 3 (each within the scatter of the next); then compound 2.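

Putting 4-hydroxy-5-(hydroxymethyl)oxolan-2-yl in place of (2,2-dimethyl-1,3-dioxolan-4-yl)methyl on the aromatic nitrogen gives a 13-fold lower number from compound 2 to compound 3 (1.13 log units; beyond the scatter), yet only a 1.0-fold higher number from compound 1 to compound 3 (0.01 log units; within the scatter). A group with hydrogen-bond donors can therefore sit at this position and match compound 1 within the scatter. The apparent size of this exchange depends on the partner chosen, because of one thing alone: the fact that compounds 1 and 2 differ only in the configuration as drawn

Going by these compounds, whether the hydroxyl groups or the ring itself carry this result stays open, as does the role of the stereocentres in compound 3. How an amine or a longer alkyl chain would behave on this nitrogen is also unknown.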